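Thiophen-3-yl in place of thiophen-2-yl at the assay limit

The source may hold more compounds than are shown below. What is called first, only, known or untested is meant among the compounds shown, and "the series" means these compounds.

Compound 3 `Cc1ncnc2c1c(-c1cccs1)cn2[C@@H]1O[C@H](CO)[C@@H](O)[C@H]1O` is tested in a functional assay on HCT-116 cells (Homo sapiens), read by MTT assay, with a stated time of 72 h (on this read-out lower numbers stand for stronger inhibition and higher numbers for weaker inhibition), where compound 3 gives > 20000 nM, a limit and not a number. Compound 1 `CNc1ncnc2c1c(-c1ccsc1)cn2[C@@H]1O[C@H](CO)[C@@H](O)[C@H]1O`, which already carries thiophen-3-yl, gives > 20000 nM, also a limit. Compound 2 `CN(C)c1ncnc2c1c(-c1ccsc1)cn2[C@@H]1O[C@H](CO)[C@@H](O)[C@H]1O`, with thiophen-3-yl as well, gives > 20000 nM, again a limit. Together these results make up (the limit of > 20000 nM in this assay, at which 3 of the 3 values shown sit). Among the measured compounds shown here, the one measured step, a step that the two limits leave unreadable from compound 1 to compound 2, involves a different change and gives no size to carry over. Compound 4 `Cc1ncnc2c1c(-c1ccsc1)cn2[C@@H]1O[C@H](CO)[C@@H](O)[C@H]1O` has the same atoms as compound 3, joined differently: thiophen-3-yl in place of thiophen-2-yl on an aromatic carbon. The estimated step is a number no higher from compound 3 to compound 4 (the limit leaves the size open), and no clear direction is expected. Compound 4 is expected near 20000 nM, with an estimated range of 5000 nM to 40000 nM.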

Compound 4, half-maximal inhibitory concentration: 460 nM
Estimate against measurement, compound 4: 43-fold (1.64 log units) above; measured number outside the range, below it.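

In this assay, the point at which the thiophene is attached matters: thiophen-3-yl in place of thiophen-2-yl gives an at least 43-fold lower number from compound 3 to compound 4 (1.63 log units; beyond the scatter). With thiophen-3-yl in place, the neighbouring substituent on the core matters too: methyl in place of dimethylamino gives an at least 43-fold lower number from compound 2 to compound 4 (1.63 log units; beyond the scatter), and methyl in place of methylamino gives an at least 43-fold lower number from compound 1 to compound 4 (1.63 log units; beyond the scatter). Among these compounds, only the pairing of thiophen-3-yl with methyl gives a measurable value, and the rest stay at a limit of the assay: the limit of > 20000 nM in this assay, at which 3 of the 4 values shown sit.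

As far as these compounds go, whether an ethyl chain in place of the methyl, or a phenyl ring in place of the thiophene, would keep this activity remains open. From the compounds shown here alone, the full size of each step also remains open, as all three starting values are limits.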